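The source may report more compounds than this note shows. Statements on the series, on what has been measured and on what is new or still open speak of the compounds shown alone.

Compound 1 `CC1(C)CC12NC(=O)N(NC(=O)c1ccccc1)C2=O` gives 300 mg/kg in a functional assay on the whole organism (Hindlimb) for inhibition, with Mus musculus as the target, with a stated time of 0.5 h; a lower number here means that less compound is needed, a higher number that more compound is needed for the effect.
Compound 2 `CC1(C)CC12NC(=O)N(NC(=O)c1ccc(Cl)cc1)C2=O` gives 100 mg/kg in this assay.
Compound 3 `COc1ccc(C(=O)NN2C(=O)NC3(CC3(C)C)C2=O)cc1` gives 100 mg/kg in this assay.

Compound 3 stands level with compound 2 at the digits shown, and together these two carry the lowest numbers of the three, while compound 1 lies furthest away, with a higher number. The two steps that lead to this pair are a 3.0-fold lower number from compound 1 to compound 2 (0.48 log units; beyond the scatter) and a 3.0-fold lower number from compound 1 to compound 3 (0.48 log units; beyond the scatter); the step between the pair itself is no change at the digits printed from compound 2 to compound 3 (within the scatter).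

Compound 4 `CN(C)c1ccc(C(=O)NN2C(=O)NC3(CC3(C)C)C2=O)cc1` is not yet measured. The change from compound 3 to compound 4 is dimethylamino in place of methoxy on an aromatic carbon. Among the measured compounds shown here, no measured step touches a dimethylamino group, so the only bearing steps are those around compound 3: both substitutions on the aromatic ring lowered the number modestly relative to compound 1, and exchanging chloro for methoxy left it unchanged within the scatter. Compound 4 is therefore expected to stay close to compound 3, with the step of no change at the digits printed from compound 3 to compound 4 (within the scatter) estimated to lie within the scatter. For compound 4 in this assay the estimate is 100 mg/kg, with a range from 50 mg/kg to 300 mg/kg.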

Compound 4, minimum effective dose: 300 mg/kg
Compound 4: middle estimate off by 3.0-fold (0.48 log units), on the low side, and the stated range covers the measured number.
By their numbers in this assay, from the lowest: compounds 2 and 3 (each within the scatter of the next); then compounds 1 and 4 (each within the scatter of the next).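

At this place on the aromatic ring, para to a large group, the groups do not all behave alike: in this assay, where chloro and methoxy had matched, dimethylamino in place of methoxy gives a 3.0-fold higher number from compound 3 to compound 4 (0.48 log units; beyond the scatter) and dimethylamino in place of chloro gives a 3.0-fold higher number from compound 2 to compound 4 (0.48 log units; beyond the scatter). The lowering seen with those two groups is therefore not shared by every substituent here, since dimethylamino in place of hydrogen gives no change at the digits printed from compound 1 to compound 4 (within the scatter). Nothing available on these compounds accounts for the difference between dimethylamino and methoxy.

From the compounds shown here alone, it remains open whether a plain amino group or a methylamino group at this place would follow dimethylamino or methoxy. Equally open is where a fluoro group or a carboxylic acid would fall among these compounds.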